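The compounds below may be only part of what the source reports. "The series", "measured", "known", "first", "only" and "open" are said of these compounds alone.

Measured so far in an ADME assay on S9 fraction from liver (Rattus norvegicus) for metabolic stability, with a stated time of 1 h; a lower number here means that less of the compound is left, a higher number that more of the compound is left:
- compound 1 `N#Cc1cnc(NCc2cnccc2C(F)(F)F)cc1N[C@H]1CC[C@@H](C(N)=O)CC1`: 30%
- compound 2 `CNC(=O)[C@H]1CC[C@@H](Nc2cc(NCc3cnccc3C(F)(F)F)ncc2C#N)CC1`: 53%

Compound 2, at 53%, holds the higher of the two numbers in this assay.

The next compound is compound 3 `CN(C)C(=O)[C@H]1CC[C@@H](Nc2cc(NCc3cnccc3C(F)(F)F)ncc2C#N)CC1`. Its change from compound 2 is methyl in place of hydrogen on an amide-type nitrogen, again methyl in place of hydrogen on an amide-type nitrogen. Among the measured compounds shown here, only one measured step bears on this: a number 23 percentage points higher from compound 1 to compound 2 (beyond the scatter), the same replacement made once already on that nitrogen, and a modest rise beyond the scatter. A single step cannot show whether a second methyl repeats it, so the direction is carried over with caution and the size is reduced. The expected change is a number 9 percentage points higher from compound 2 to compound 3 (within the scatter), an estimate with real doubt about whether it clears the scatter. For compound 3 the estimated value is 62%, with an expected range of 40% to 82%.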

Compound 3, percent of the compound remaining: 22%
The estimate for compound 3 lay 40 percentage points above the measured number; measured number outside the range, below it.
By their numbers in this assay, from the lowest: compounds 3 and 1 (each within the scatter of the next); then compound 2.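

In this assay the second methyl on the amide-type nitrogen does not repeat the first: a number 23 percentage points higher from compound 1 to compound 2 (beyond the scatter) is followed by a number 31 percentage points lower from compound 2 to compound 3 (beyond the scatter) for the same replacement, so the sign of this change at this position depends on what the nitrogen already carries. Read as one change, dimethylamino in place of amino on the carbonyl carbon gives a number 8 percentage points lower from compound 1 to compound 3 (within the scatter) and thus no separation of those two compounds, which leaves methylcarbamoyl in compound 2 as the only one of the three amides that stands apart. Nothing among the data shown explains the reversal.

As far as these compounds go, whether the reversal follows from the added methyl itself or from the loss of the amide hydrogen remains open. An ethyl group on the same nitrogen, a longer chain there, or a carboxylic acid in place of the amide would help separate these readings in this assay for this series.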